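A larger two-ring group replaces the 1H-pyrrol-3-yl group

The source may hold more compounds than are shown below. What is called first, only, known or untested is meant among the compounds shown, and "the series" means these compounds.

Going by the values given here, compound 2 `CCOC(=O)C1=C(Nc2ccccc2)S/C(=C\c2cc[nH]c2)C1=O` holds the lower of the two numbers known so far: in a functional assay on JAR cells (Homo sapiens) for inhibition, read by MTT assay, with a stated time of 72 h, tested at 10 uM (a lower number here means less inhibition, a higher number more inhibition at the concentration tested (going by the name of the read-out)), compound 2 gives 19.5%, while compound 1 `CCOC(=O)C1=C(Nc2ccccc2)S/C(=C\c2ccccc2O)C1=O` gives 89.4%. Among the compounds with values here, the one measured step, a number 69.9 percentage points lower from compound 1 to compound 2 (beyond the scatter), shows that the group on the double-bonded chain carbon bound to a double-bonded ring carbon sways this read-out strongly. Compound 3 `CCOC(=O)C1=C(Nc2ccccc2)S/C(=C\c2cc3ncccc3[nH]2)C1=O` alters that same group again: a group of 9 heavy atoms (7 carbon, 2 nitrogen; one five-membered aromatic ring with 1 hetero atom, one six-membered aromatic ring with 1 hetero atom) in place of a group of 5 heavy atoms (4 carbon, 1 nitrogen; one five-membered aromatic ring with 1 hetero atom), on a double-bonded chain carbon bound to a double-bonded ring carbon. Within the data shown here, no measured step covers this exact replacement, so the direction rests only on the observation that a change at this position moved the number far. Because the single swing on record, a number 69.9 percentage points lower from compound 1 to compound 2 (beyond the scatter), was large, a step of comparable reach in either direction cannot be excluded. The estimate leans toward a moderate rise, a number 22.5 percentage points higher from compound 2 to compound 3 (beyond the scatter), with wide bounds. Compound 3 is therefore expected to give about 42%, between 10% and 78%.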

Compound 3, a percentage reported as inhibition, at one concentration (the size of the read-out at that concentration, not a potency): 74.8%
Compound 3: the middle estimate sits 32.8 percentage points below what was measured, and the stated range covers the measured number.
By their numbers in this assay, from the lowest: compound 2; then compound 3; then compound 1.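

In this assay, the place on a double-bonded chain carbon bound to a double-bonded ring carbon now moves the number upward as well as downward: adding a six-membered aromatic ring with 1 hetero atom to the five-membered aromatic ring gives a number 55.3 percentage points higher from compound 2 to compound 3 (beyond the scatter), so the low number does not hold for every group with a five-membered aromatic ring here. The 2-hydroxyphenyl group is also no longer alone in giving a high number, since the replacement that contains no oxygen gives only a number 14.6 percentage points lower from compound 1 to compound 3 (beyond the scatter), a modest step though beyond the scatter. Nothing at hand gives a reason for either step.

The compounds shown leave open whether the added ring or its nitrogen carries the rise, which a 1H-indol-2-yl group, with carbon in place of that nitrogen, would test. They also leave open whether the hydroxyl of compound 1 matters, which a plain phenyl or a 2-methoxyphenyl group would test.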